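Pyridin-2-yl for 3-fluorophenyl on the fused azole nitrogen

The source may hold more compounds than are shown below. What is called first, only, known or untested is meant among the compounds shown, and "the series" means these compounds.

Three compounds of the series have numbers in a functional assay on Hep 3B2 cells (Homo sapiens) for inhibition, read by sulforhodamine B assay, with a stated time of 72 h, tested at 10 uM (on this read-out higher numbers stand for more inhibition at the one concentration tested (going by the name of the read-out) and lower numbers for less inhibition), so far. Compound 2 `C[C@H](Nc1ncnc2[nH]cnc12)c1nn(-c2cccc(F)c2)c2cc(F)ccc12` gives 28% in this assay and stands second highest of the three. Compound 1 `Cc1ccc2c(c1)c([C@H](C)Nc1ncnc3[nH]cnc13)nn2-c1cccnc1` gives 8% in this assay, a number well below that of compound 2 and beyond the scatter. Compound 3 `C[C@H](Nc1nc(N)nc(N)c1C#N)c1nn(-c2cccc(S(C)(=O)=O)c2)c2cc(Cl)ccc12` gives 72% in this assay, far above compound 2 and again beyond the scatter. Among the measured compounds shown here, compound 1 and compound 3 each differ from compound 2 at more than one place, so no single-change step between measured compounds is known.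

Compound 4 `C[C@H](Nc1ncnc2[nH]cnc12)c1nn(-c2ccccn2)c2cc(F)ccc12` is the next compound for this assay. It differs from compound 2 in one place: pyridin-2-yl in place of 3-fluorophenyl on an aromatic nitrogen. For the measured compounds named here, with no single-change step available, the expectation rests on the values of compound 2 and compound 1 only; a modest loss, possibly within the scatter, is expected, so the step of a number 10 percentage points lower from compound 2 to compound 4 (within the scatter) is estimated as small and downward. Compound 4 is expected to give about 18% in this assay, within a range from 0% to 40%.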

Compound 4, a percentage reported as inhibition, at one concentration (the size of the read-out at that concentration, not a potency): 12%
The estimate for compound 4 lay 6 percentage points above the measured number; low and high end bracket the measured number.
By their numbers in this assay, from the lowest: compounds 1 and 4 (each within the scatter of the next); then compound 2; then compound 3.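

In this assay, among the compounds shown here, pyridin-2-yl in place of 3-fluorophenyl on the aromatic nitrogen gives a number 16 percentage points lower from compound 2 to compound 4 (beyond the scatter) as the first single-change reading. For the compounds shown here, with the rest of the structure held constant, the group at this position alone moves the read-out, which the earlier compounds could not show because they differ at more than one place. The change removes the fluorine and adds a ring nitrogen with one hydrogen-bond acceptor, but nothing at hand bears on why the number falls.

The compounds shown do not separate the loss of the fluorine from the entry of the ring nitrogen, and an unsubstituted phenyl or a pyridin-4-yl at this position would speak to that. From the compounds shown here alone, how much this position contributes to the much higher number of compound 3 also stays open.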